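The compounds below may be only part of what the source reports. "The series", "measured", "known", "first", "only" and "open" are said of these compounds alone.

Compound 1 `CCCCSc1nc(N)nc2c1ncn2/C=C1/CC1(CO)CO`: > 20000 nM
Compound 2 `CN(C)c1nc(N)nc2c1ncn2/C=C1/CC1(CO)CO`: > 20000 nM

In an ADME assay on BCBL1 cells (Homo sapiens) for cytotoxicity, with a stated time of 7 days (on this read-out lower numbers stand for higher toxicity in this test and higher numbers for lower toxicity in this test), compound 1 gives only a limit of the test, > 20000 nM. In this assay compound 2 likewise gives only a limit, > 20000 nM. Compound 3 `CSc1nc(N)nc2c1ncn2/C=C1/CC1(CO)CO` is not yet measured and differs from compound 2 by methylsulfanyl in place of dimethylamino on an aromatic carbon. Going by the values given here, the one measured step that bears on it, a step that the two limits leave unreadable from compound 1 to compound 2, has no readable size, since both of its values sit at the limit of > 20000 nM in this assay, at which 2 of the 2 values shown sit. Compound 3 is therefore expected to sit at that same limit, with an estimate of 20000 nM ranging from 10000 nM to 60000 nM. The expected step is a number no higher from compound 2 to compound 3 (the limit leaves the size open).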

Compound 3, half-maximal cytotoxic concentration: > 20000 nM
Compound 3: only a limit was reported; the forecaster's own chance of this, stated with the estimate: 90%; the middle value lies on the limit itself.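

Going by these compounds alone, no step between compound 1, compound 2 and compound 3 can be read, since all three give only a limit: the limit of > 20000 nM in this assay, at which 3 of the 3 values shown sit. As far as these compounds go, whether butylsulfanyl, dimethylamino and methylsulfanyl differ at all on this read-out stays open.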